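The source may hold more compounds than are shown below. What is called first, only, known or untested is meant among the compounds shown, and "the series" means these compounds.

Three compounds have been measured in an assay on membranes from brain for displacement of a labelled ligand from Neuronal acetylcholine receptor; alpha4/beta2 (Rattus norvegicus), with a stated time of 3 h; on this read-out lower numbers stand for stronger inhibition and higher numbers for weaker inhibition:

Compound 1, `Oc1cccc(/C=C2\CCCN=C2c2cccnc2)c1`, gives 1170 nM.
Compound 2, `COc1cc(OC)c(/C=C2\CCCN=C2c2cccnc2)c(OC)c1`, gives 60 nM.
Compound 3, `COc1ccc(/C=C2\CCCN=C2c2cccnc2)c(OC(C)=O)c1`, gives 770 nM.

Among these three numbers, compound 3 stands second highest. Its nearest neighbour is compound 1, whose number is slightly higher but still within the usual scatter of such measurements, so the two cannot be told apart with confidence. Compound 2, which carries three methoxy groups on its outer ring, gives a much lower number, and that gap lies well beyond the scatter.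

The next compound, compound 4, `COc1ccc(/C=C2\CCCN=C2c2cccnc2)c(OC)c1`, differs from compound 3 in one place: methyl in place of acetyl on an oxygen on an aromatic ring. After this change compound 4 carries two methoxy groups on its outer ring. For the measured compounds named here, no pair of measured compounds shows this exact change, so there is no measured step to lean on. What can be said is that compound 2, the compound richest in methoxy groups, gives the lowest number, while compound 3 with its acetoxy group sits far higher. On that basis a step toward a lower number is expected, likely beyond the scatter, though not all the way to compound 2.

Compound 4 is expected to give about 300 nM, within a range from 80 nM to 1200 nM. This corresponds to an expected step of a 2.6-fold lower number from compound 3 to compound 4 (0.41 log units; beyond the scatter).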

Compound 4, inhibition constant: 250 nM
Estimate against measurement, compound 4: 1.2-fold (0.08 log units) above, within the range that was stated.
By their numbers in this assay, from the lowest: compound 2; then compound 4; then compounds 3 and 1 (each within the scatter of the next).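

In this assay, replacing acetoxy with methoxy on the aromatic ring gives a 3.1-fold lower number from compound 3 to compound 4 (0.49 log units; beyond the scatter). This is the first single change among these compounds to show that the group on this oxygen can shift the number beyond the scatter, with methoxy going with the lower number in this pair. The second step concerns a different place on the outer ring: hydrogen in place of methoxy on an aromatic carbon gives a 4.2-fold higher number from compound 2 to compound 4 (0.62 log units; beyond the scatter), so in this pair the extra methoxy group goes with the lower number.

On these data alone, these two pairs cannot say whether the first step depends on gaining the methyl or on losing the acetyl, and how a longer chain such as ethoxy, or an amine, would read in place of methoxy on the aromatic ring remains open. Nothing measured here accounts for either step, so the reason for these differences also stays open.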